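This account rests on a few compounds, and the source may have more. Where it says the series, first, only, none or still open, it means among the compounds named here.

Measured compounds in a functional assay on HL-60 cells (Homo sapiens) for cytotoxicity, read by WST assay, with a stated time of 48 h; a lower number here means a stronger inhibitor, a higher number a weaker inhibitor:
- compound 1, `COc1ccccc1/C=C/C[C@H]1C[C@@H]([C@@H](O)c2ccccc2)CO[C@@H]1c1ccccc1`, where compound 1 gives 10100 nM
- compound 2, `O[C@@H](c1ccccc1)[C@H]1CO[C@H](c2ccccc2)[C@@H](C/C=C/C2CCCCC2)C1`, where compound 2 gives 6260 nM

Compound 2 has the lowest of the two numbers in this assay, but its nearest neighbour is compound 1, and the step of a 1.6-fold lower number from compound 1 to compound 2 (0.21 log units; within the scatter) lies within the scatter, so the two measured compounds cannot be told apart on these data.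

Compound 3, `O[C@@H](c1ccccc1)[C@H]1CO[C@H](c2ccccc2)[C@@H](C/C=C/c2cccc(F)c2)C1`, has not yet been measured in this assay. It differs from compound 2 in one place: 3-fluorophenyl in place of cyclohexyl on a double-bonded chain carbon bound to a double-bonded chain carbon.

Among the compounds with values here, the only measured step that bears on this change is a 1.6-fold lower number from compound 1 to compound 2 (0.21 log units; within the scatter), in which a cyclohexyl replaced a 2-methoxyphenyl on a double-bonded chain carbon bound to a double-bonded chain carbon without moving the number beyond the scatter. Going back from cyclohexyl to an aromatic ring, now a 3-fluorophenyl, at the same place is therefore expected to leave the number near that of compound 2, with no step beyond the scatter in either direction; the expected step is a 1.1-fold higher number from compound 2 to compound 3 (0.05 log units; within the scatter). Compound 3 is thus estimated at 7000 nM in this assay, within a range from 3000 nM to 16000 nM.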

Compound 3, half-maximal inhibitory concentration: 9170 nM
Beside the measured number, compound 3's estimate is 1.3-fold (0.12 log units) below it; the measured number falls inside the stated range.
By their numbers in this assay, from the lowest: compounds 2, 3 and 1 (each within the scatter of the next).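

In this assay, replacing the cyclohexyl on a double-bonded chain carbon bound to a double-bonded chain carbon with 3-fluorophenyl gives a 1.5-fold higher number from compound 2 to compound 3 (0.17 log units; within the scatter), so a non-aromatic ring of carbon only and a fluorine-bearing aromatic ring cannot be told apart at this position. The two aromatic groups cannot be separated either, with a 1.1-fold lower number from compound 1 to compound 3 (0.04 log units; within the scatter), so the flat reading seen earlier for a single pair now holds for all three pairs among compounds 1, 2 and 3, each with a different six-membered ring at this place. Nothing at hand offers an explanation for why these three compounds read alike.

On these data alone, all three compounds carry a six-membered ring at this place, so it remains open whether any group here can move the number beyond the scatter, for example an amine, a carboxylic acid or a short alkyl chain in place of the ring. All three also keep the double bond in the chain, which leaves open what a fully saturated chain would give.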